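Moving the chlorine from compound 2 to compound 4

This account rests on a few compounds, and the source may have more. Where it says the series, first, only, none or still open, it means among the compounds named here.

Compound 1 `COc1cc2ncnc(NNC(=S)NC(=O)c3ccc(C(F)(F)F)cc3)c2cc1OC`, compound 2 `O=C(NC(=S)NNc1ncnc2ccccc12)c1cccc(Cl)c1` and compound 3 `COc1cc2ncnc(NNC(=S)NC(=O)c3cccc(Cl)c3)c2cc1OC` were tested in a functional assay on KB cells (Homo sapiens) for cytotoxicity, read by MTT assay, with a stated time of 72 h; a lower number here means a stronger inhibitor, a higher number a weaker inhibitor. Compound 1 gives 8840 nM, compound 2 gives 4740 nM and compound 3 gives 4830 nM; compound 2 has the lowest number of the three, but its gaps to compound 3 and to compound 1 both lie within the scatter. Going by the values given here, the single step between measured compounds, a 1.8-fold lower number from compound 1 to compound 3 (0.26 log units; within the scatter), also stays within the scatter. Compound 4 `O=C(NC(=S)NNc1ncnc2ccccc12)c1ccc(Cl)cc1` differs from compound 2 by 4-chlorophenyl in place of 3-chlorophenyl on a carbonyl carbon. Among the compounds with values here, no measured step exchanges 3-chlorophenyl for 4-chlorophenyl, so nothing measured bears directly on this change, and the one step seen on that ring stayed within the scatter. Compound 4 is therefore expected to show a step of a 1.1-fold higher number from compound 2 to compound 4 (0.02 log units; within the scatter) that stays within the scatter. Compound 4 is estimated at 5000 nM, between 2000 nM and 12500 nM.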

Compound 4, half-maximal inhibitory concentration: 3940 nM
The estimate for compound 4 lay 1.3-fold (0.10 log units) above the measured number; the measured number falls inside the stated range.
By their numbers in this assay, from the lowest: compounds 4, 2, 3 and 1 (each within the scatter of the next, the first and the last beyond it).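

In this assay the exchange of 3-chlorophenyl for 4-chlorophenyl on the carbonyl carbon now has a measured step, a 1.2-fold lower number from compound 2 to compound 4 (0.08 log units; within the scatter), the first on this change. On the core of compound 2, the two chlorophenyl groups therefore cannot be told apart in this assay. Nothing available explains this result.

From the compounds shown here alone, it remains open whether the same exchange would also stay within the scatter on the core of compound 3. Going by these compounds, it also remains open whether an amine or a carboxylic acid on this ring would give a step beyond it.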